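A few compounds are considered here, and "the series" means these few. Any claim that something is new, unique, unknown or untested is made for them only; others in the source may bear on it.

Working notes on the amide series. Of the compounds shown here, two have been measured so far. Compound 1 `Cc1cc(Cl)ccc1C(=O)Nc1ccc(Cl)c(-c2nnc3c(Cl)cccn23)c1` in a functional assay on MDA-MB-468 cells (Homo sapiens) for antiproliferative activity, read by MTT assay, with a stated time of 72 h (a lower number here means a stronger inhibitor, a higher number a weaker inhibitor), gives 34300 nM. Compound 2 `O=C(Nc1ccc(Cl)c(-c2nnc3c(Cl)cccn23)c1)c1ccc(Cl)cc1Cl` in this assay gives 21600 nM. Within the data shown here, the only single-point step measured, a 1.6-fold lower number from compound 1 to compound 2 (0.20 log units; within the scatter), is too small to separate the two. Compound 2 thus holds the lower of the two numbers, with compound 1 as its nearest neighbour at a gap that lies within the scatter, so no order between them can be claimed.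

The next compound, compound 3 `O=C(Nc1ccc(Cl)c(-c2nnc3c(Cl)cccn23)c1)c1ccon1`, has not yet been measured in this assay. It differs from compound 2 by 1,2-oxazol-3-yl in place of 2,4-dichlorophenyl on a carbonyl carbon. Among the measured compounds shown here, the one measured step exchanged a single substituent on the aryl group of the amide, whereas here the whole aryl group is exchanged; no measured step speaks to a change of this kind, so the direction cannot be derived from the data and the expectation rests on the small size of the one step seen. The estimated step of a 1.9-fold higher number from compound 2 to compound 3 (0.27 log units; within the scatter) is therefore expected to be small. Compound 3 is expected at 40000 nM, with a range from 12000 nM to 130000 nM.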

Compound 3, half-maximal inhibitory concentration: > 100000 nM
Compound 3 gave a limit, no number (the forecaster's own chance of this, stated with the estimate: 20%); middle value at least 2.5-fold (0.39 log units) from the limit.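

The read-out of compound 3 in this assay is a limit of the assay and not a number: the limit of > 100000 nM in this assay, at which 1 of the 3 values shown sits. The earlier step exchanged only one substituent on the aryl group of the amide and stayed within the scatter, whereas replacing the whole aryl group on the carbonyl carbon gives an at least 4.6-fold higher number from compound 2 to compound 3 (0.66 log units; beyond the scatter) and an at least 2.9-fold higher number from compound 1 to compound 3 (0.46 log units; beyond the scatter). Among these compounds, this is the first sign that the group on this carbonyl carbon matters in this assay: 1,2-oxazol-3-yl goes with a weaker result than either substituted phenyl group, and the true size of the gap remains unknown.

The exchange alters the ring size, the hetero atoms and the chlorine substituents at once, so the compounds shown cannot say which of these changes goes with the loss. Also open, from the compounds shown here alone, is where a phenyl group without chlorine, or a phenyl group carrying an amine or a carboxylic acid, would stand relative to the 2,4-dichlorophenyl and 1,2-oxazol-3-yl groups in this assay.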